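Swapping the aryl group of compound 3 for ethynyl

The source may hold more compounds than are shown below. What is called first, only, known or untested is meant among the compounds shown, and "the series" means these compounds.

In a functional assay on KYSE-70 cells for antiproliferative activity against KYSE-70 cell line (Homo sapiens), read by MTT assay, with a stated time of 72 h (a higher number here means a weaker inhibitor, a lower number a stronger inhibitor), compound 1 `O=C(Nc1cccc(F)c1)c1cc(=O)[nH]c2cc(-c3ccc(F)cc3)ccc12` gives 3300 nM. Compound 2 `Nc1ccc(-c2ccc3c(C(=O)Nc4cccc(F)c4)cc(=O)[nH]c3c2)cc1` reads > 20000 nM, which is a limit of the assay. Compound 3 `Cc1cc(-c2ccc3c(C(=O)Nc4cccc(F)c4)cc(=O)[nH]c3c2)c(C)cc1F` reads > 20000 nM, also a limit, so it has no number of its own. Compound 4 `C#Cc1ccc2c(C(=O)Nc3cccc(F)c3)cc(=O)[nH]c2c1` differs from compound 3 as follows: ethynyl in place of 4-fluoro-2,5-dimethylphenyl on an aromatic carbon. Among the compounds with values here, two measured steps bear on this aromatic carbon: an at least 6.0-fold higher number from compound 1 to compound 2 (0.78 log units; beyond the scatter) and an at least 6.0-fold higher number from compound 1 to compound 3 (0.78 log units; beyond the scatter). Within the data shown here, both moved away from the one real number, and neither involves ethynyl, so the expectation is loose. The expected step is an at least 1.6-fold lower number from compound 3 to compound 4 (0.22 log units; that floor lies within the scatter), a modest move toward a lower number. The estimated value for compound 4 is 12000 nM, with an expected range of 3000 nM to 40000 nM.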

Compound 4, half-maximal inhibitory concentration: 9500 nM
Estimate against measurement, compound 4: 1.3-fold (0.10 log units) above, within the range that was stated.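

In this assay, this aromatic carbon keeps a readable number with ethynyl, a group without a ring, whereas two of the larger aryl groups do not: an at least 2.1-fold lower number from compound 3 to compound 4 (0.32 log units; beyond the scatter), and an at least 2.1-fold lower number from compound 2 to compound 4 (0.32 log units; beyond the scatter). The ring itself is therefore not required, yet ethynyl does not match 4-fluorophenyl, with a 2.9-fold higher number from compound 1 to compound 4 (0.46 log units; beyond the scatter). Both lower steps are only floors, since compound 2 and compound 3 are limits and not numbers: the limit of > 20000 nM in this assay, at which 2 of the 4 values shown sit.

Going by these compounds, whether a nitrile, a longer alkyne chain or a carboxylic acid on this carbon would give a lower number than compound 1 stays open.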